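Swapping Cyclopropyl for Methoxy on the Side Chain

The source may hold more compounds than are shown below. What is called first, only, known or untested is meant among the compounds shown, and "the series" means these compounds.

Of the compounds shown here, three have been measured in an assay on isolated protein for inhibition of serine protease 1 (Homo sapiens), read by fluorescence; a higher number here means a weaker inhibitor, a lower number a stronger inhibitor. Among the compounds with values here, compound 1 `COc1cc(C(=O)N2C[C@@H](n3cc(C4CC4)nn3)C[C@H]2C(=O)N2CC[C@@H](c3ccccc3)C2)ccc1CN` gives 330 nM, and compound 3 `COc1cc(C(=O)N2C[C@@H](n3cc(C4CC4)nn3)C[C@H]2C(=O)N[C@H]2C[C@@H]2c2ccccc2)ccc1CN` gives 960 nM; the one step joining them, a 2.9-fold higher number from compound 1 to compound 3 (0.46 log units; beyond the scatter), concerns the (2-phenylcyclopropyl)amino in place of 3-phenylpyrrolidin-1-yl on a carbonyl carbon. Compound 2 `CNC(=O)[C@@H]1C[C@H](N2CCc3c(cccc3OCCC3CC3)C2)CN1C(=O)c1ccc(CN)c(OC)c1` stands apart from both: in this assay compound 2 gives 2 nM, the lowest of the three numbers, with compound 1 its nearest neighbour and compound 3 its furthest, each gap well beyond the scatter.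

Compound 4 `CNC(=O)[C@@H]1C[C@H](N2CCc3c(cccc3OCCOC)C2)CN1C(=O)c1ccc(CN)c(OC)c1` differs from compound 2 in one place: methoxy in place of cyclopropyl on a saturated chain carbon, two bonds along the chain from an oxygen on an aromatic ring. Within the data shown here, no measured step bears on this change. Among the measured compounds shown here, the single step known touches a different part of the molecule, and the chain carrying the cyclopropyl appears in compound 2 alone among the measured compounds. With nothing to anchor it, the expectation rests on the strength of compound 2 at 2 nM and allows for a modest loss. The step is therefore estimated as a 3.0-fold higher number from compound 2 to compound 4 (0.48 log units; beyond the scatter), a small rise in the number. Compound 4 is thus expected to give 6 nM in this assay, within a range from 1.5 nM to 25 nM.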

Compound 4, half-maximal inhibitory concentration: 8 nM
Estimate against measurement, compound 4: 1.3-fold (0.12 log units) below; measured number inside the range.
By their numbers in this assay, from the lowest: compound 2; then compound 4; then compound 1; then compound 3.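

In this assay the result gives the first measured size for a change on this side chain: a 4.0-fold higher number from compound 2 to compound 4 (0.60 log units; beyond the scatter), with 2-methoxyethoxy standing in place of 2-cyclopropylethoxy. The swap takes away a three-membered carbon ring and brings in an oxygen with a hydrogen-bond acceptor, yet the step stays modest and compound 4 remains at 8 nM in the same assay, so in this pair the cyclopropyl ring is not required for a low number, even though compound 2 with the ring holds the lower value. No available evidence explains why the number rises with this change.

These two compounds cannot separate the loss of the ring from the gain of the oxygen, since both happen in the same step. Going by these compounds, how an open carbon chain such as propyl, a hydroxyl or an amine at the end of the chain, or a longer chain carrying the same methoxy would read at this place remains open.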